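This account rests on a few compounds, and the source may have more. Where it says the series, first, only, none or still open, it means among the compounds named here.

Working notes on the series

Three compounds have been run in a functional assay on HepG2 cells (Homo sapiens) for inhibition, read by CCK-8 assay, with a stated time of 48 h (on this read-out higher numbers stand for weaker inhibition and lower numbers for stronger inhibition), so far. Compound 1 `Cc1ccc(C2=NN(C3=NC(c4ccccc4)CS3)C(c3ccc4ccccc4c3)C2)cc1` and compound 2 `Brc1ccc(C2=NN(C3=NC(c4ccccc4)CS3)C(c3ccc4ccccc4c3)C2)cc1` share one core; compound 3 `O=C1CSC(N2N=C(c3ccc(Br)cc3)CC2c2cccc3ccccc23)=N1` carries a second core, and how the two cores differ is not broken down here. In this assay compound 1 gives 14700 nM, compound 2 gives 20300 nM and compound 3 gives 13400 nM. All three numbers sit close together, and none of the gaps between them is reported as beyond the scatter, so no order among them can be read.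

Within the data shown here, the one matched pair within the measured set is compound 2 against compound 1, which differ by methyl in place of bromo on an aromatic carbon. That step reads a 1.4-fold lower number from compound 2 to compound 1 (0.14 log units; within the scatter).

Compound 4 `Cc1ccc(C2=NN(C3=NC(=O)CS3)C(c3cccc4ccccc34)C2)cc1` has not yet been measured. It relates to compound 3 in the same way, by methyl in place of bromo on an aromatic carbon; the place of the change is the same in its printed words for both pairs, so this is the same change made on the second core. The expectation is that the step from compound 3 to compound 4 will resemble the earlier one, because a 1.4-fold lower number from compound 2 to compound 1 (0.14 log units; within the scatter) was small, and so is estimated at a 1.3-fold lower number from compound 3 to compound 4 (0.13 log units; within the scatter). On that basis compound 4 is expected to give about 10000 nM in this assay, with the estimate spanning 4500 nM to 25000 nM to allow for the scatter of single measurements and for the untested core. The measured value follows.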

Compound 4, half-maximal inhibitory concentration: 8660 nM
Compound 4: middle estimate off by 1.2-fold (0.06 log units), on the high side; the range from low to high includes it.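

In this assay, replacing 4-bromophenyl with 4-methylphenyl on the second core gives a 1.5-fold lower number from compound 3 to compound 4 (0.19 log units; within the scatter). Set beside the same change on the first core, the new step agrees with the earlier one: the same change on two cores in this assay, a 1.4-fold lower number (0.14 log units; within the scatter) from compound 2 to compound 1 and a 1.5-fold lower number (0.19 log units; within the scatter) from compound 3 to compound 4, 1.1-fold (0.05 log units) apart, within the scatter of two such steps. This shows that, for these two pairs, the change carries from one core to the other without a difference that can be told from the scatter, but it does not show that the change itself has any effect on inhibition, since each step also lies within the scatter, nor does it show that two cores stand for any other core in the series.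

The compounds shown carry only bromo and methyl at this place, so it remains open what an amine, a carboxylic acid or a longer chain would do there on either core. From the compounds shown here alone, it also remains open whether any replacement at this place can move the number in this assay beyond the scatter, and, if one can, whether that larger step would carry between the two cores as closely as this small one does.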